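The compounds below may be only part of what the source reports. "The series", "measured", "known", "first", "only" and "open" are said of these compounds alone.

Compound 1, `CCN1CCc2c(sc(NC(=O)Nc3ccccc3)c2C(N)=O)C1`, stands in a functional assay (strain AB) with Danio rerio as the target, read by microscopy, with a stated time of 1 h (a lower number here means that less compound is needed, a higher number that more compound is needed for the effect), only at a limit of the assay: in this assay compound 1 gives > 25000 nM. The same holds for compound 2, `CCN1CCc2c(sc(NC=O)c2C(N)=O)C1`, which in this assay gives > 25000 nM, again a limit rather than a number. Within the data shown here, the single measured step, hydrogen in place of anilino on a carbonyl carbon, is a step that the two limits leave unreadable from compound 1 to compound 2, because of the limit of > 25000 nM in this assay, at which 2 of the 2 values shown sit. Compound 3, `CCN1CCc2c(sc(NC(=O)Nc3ccc(-c4ccccc4)cc3)c2C(N)=O)C1`, differs from compound 1 by phenyl in place of hydrogen on an aromatic carbon. Among the measured compounds shown here, no measured step involves a phenyl entering at this place, and the one known step gives no readable size, so nothing in these values points to a direction for compound 3. Compound 3 is therefore expected to sit near the same limit, with an estimated value of 25000 nM and an expected range from 3000 nM to 100000 nM, that is an expected step of a number no higher from compound 1 to compound 3 (the limit leaves the size open).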

Compound 3, half-maximal effective concentration: 3390 nM
Compound 3: middle estimate off by 7.4-fold (0.87 log units), on the high side; measured number inside the range.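

Phenyl in place of hydrogen on this aromatic carbon, para to a large group, gives in this assay an at least 7.3-fold lower number from compound 1 to compound 3 (0.86 log units; beyond the scatter). Among these compounds, this is the first change with a direction that can be read, and it shows that adding an aromatic ring of carbon only at this place lowers the amount of compound needed for the effect. The other step among these compounds still cannot be read: the limit of > 25000 nM in this assay, at which 2 of the 3 values shown sit.

As far as these compounds go, it remains open whether this shift needs a whole phenyl ring or would also follow from a smaller group at the same place, such as methyl, methoxy, chlorine or an amine. From the compounds shown here alone, it is equally open how a substituent on the added ring, such as a carboxylic acid, or phenyl on another carbon of the same ring would read in this assay.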